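Methoxypyridinyl Variant of a Sulfonamide Series in Rat Microsomes

The source may report more compounds than this note shows. Statements on the series, on what has been measured and on what is new or still open speak of the compounds shown alone.

In an ADME assay (liver) for metabolic stability, with Liver microsome (Rattus norvegicus) as the target, using microsomes and NADPH, with a stated time of 30 min, tested at 1 uM (a lower number here means slower removal, a higher number faster removal of the compound), compound 3 `CS(=O)(=O)Nc1cccc(-c2cc(C(O)(C(F)(F)F)C(F)(F)F)cnc2N2CCN(S(=O)(=O)c3ccc(N)nc3)CC2)c1` gives 81 mL.min-1.g-1, standing at the low end of the three measured numbers. Compound 2 `Nc1ccc(S(=O)(=O)N2CCN(c3ncc(C(O)(C(F)(F)F)C(F)(F)F)cc3-c3ccccc3O)CC2)cn1` gives 125 mL.min-1.g-1 and compound 1 `CCn1cc(-c2cc(C(O)(C(F)(F)F)C(F)(F)F)cnc2N2CCN(S(=O)(=O)c3ccc(N)nc3)CC2)cn1` gives 194 mL.min-1.g-1. The step of a 1.5-fold lower number from compound 2 to compound 3 (0.19 log units; within the scatter) stays within the scatter, whereas a 2.4-fold lower number from compound 1 to compound 3 (0.38 log units; beyond the scatter) is a modest drop, and a 1.6-fold lower number from compound 1 to compound 2 (0.19 log units; within the scatter) is also small. Compound 4 `COc1cncc(-c2cc(C(O)(C(F)(F)F)C(F)(F)F)cnc2N2CCN(S(=O)(=O)c3ccc(N)nc3)CC2)c1` carries 5-methoxypyridin-3-yl in place of 3-(methanesulfonamido)phenyl on an aromatic carbon. Among the compounds with values here, no measured step involves a 5-methoxypyridin-3-yl group, so the three steps bear on it only by showing that changing the group at this position has so far moved the number by small to modest amounts. Compound 4 is therefore expected to give a somewhat higher number, a 1.6-fold higher number from compound 3 to compound 4 (0.21 log units; within the scatter). The estimate for compound 4 is 130 mL.min-1.g-1, in the range 65 mL.min-1.g-1 to 260 mL.min-1.g-1.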

Compound 4, intrinsic clearance in microsomes: 58 mL.min-1.g-1
The estimate for compound 4 lay 2.2-fold (0.35 log units) above the measured number; measured number below the stated range.
By their numbers in this assay, from the lowest: compounds 4, 3, 2 and 1 (each within the scatter of the next, the first and the last beyond it).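

At this aromatic carbon, a group with 0 hydrogen-bond donors and a ring with 1 hetero atom replaces 3-(methanesulfonamido)phenyl in this assay with a 1.4-fold lower number from compound 3 to compound 4 (0.15 log units; within the scatter) as the step, so the two groups cannot be told apart. Against the other two groups, the change reaches beyond the scatter, with a 2.2-fold lower number from compound 2 to compound 4 (0.33 log units; beyond the scatter) and a 3.3-fold lower number from compound 1 to compound 4 (0.52 log units; beyond the scatter) as the steps, the latter being the widest span yet shown at this position. Nothing given here explains these differences. The compounds shown leave open whether the methoxy group or the ring nitrogen matters more. Plain pyridin-3-yl and 3-methoxyphenyl at this carbon would separate the two.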